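A few compounds are considered here, and "the series" means these few. Any claim that something is new, unique, unknown or untested is made for them only; others in the source may bear on it.

Measured so far in an assay on isolated protein (Oryctolagus cuniculus) with Thromboxane-A synthase (Homo sapiens) as the target, tested at 1 uM; a lower number here means less inhibition, a higher number more inhibition at the concentration tested (going by the name of the read-out):
compound 1, `CC(=O)Cn1nc(-c2cccnc2)c2ccccc2c1=O`, 13%
compound 2, `COCCn1nc(-c2cccnc2)c2ccccc2c1=O`, 55%

Among the compounds with values here, compound 2 holds the higher of the two numbers in this assay; the single measured step, a number 42 percentage points higher from compound 1 to compound 2 (beyond the scatter), is the only comparison available. Compound 3, `CC(=O)OCCn1nc(-c2cccnc2)c2ccccc2c1=O`, is the next member: acetyl in place of methyl on an oxygen on a saturated carbon. The step from compound 1 to compound 2 also exchanged an acetyl for a methoxymethyl on the saturated chain carbon bound to the aromatic nitrogen, and it was large; it bears on compound 3 only indirectly, since here the acetyl enters on the oxygen and the 2-substituted ethyl chain of compound 2 is kept. Compound 1, with its acetyl on the chain carbon, sits low, so a move back toward an acetyl is expected to cost some inhibition, though less than the full reversal. Compound 3 is therefore expected to give 35% (range 10% to 60%), a step of a number 20 percentage points lower from compound 2 to compound 3 (beyond the scatter), downward and probably beyond the scatter.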

Compound 3, a percentage reported as inhibition, at one concentration (the size of the read-out at that concentration, not a potency): 32%
Compound 3: middle estimate off by 3 percentage points, on the high side, within the range that was stated.
By their numbers in this assay, from the lowest: compound 1; then compound 3; then compound 2.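

In this assay, the change on the oxygen alone, with the ethyl chain kept, moves the number: acetyl in place of methyl gives a number 23 percentage points lower from compound 2 to compound 3 (beyond the scatter). Acetoxymethyl in place of acetyl on the saturated chain carbon bound to the aromatic nitrogen gives a number 19 percentage points higher from compound 1 to compound 3 (beyond the scatter), so an acetyl group in the side chain does not fix the number at one level, and its placement in the chain matters. Both acetyl-bearing compounds stand below compound 2, and none of the three goes against this, though no measurement here explains the order.

Open, on these data alone, is whether 2-hydroxyethyl, a 2-aminoethyl chain, a carboxylic acid or a longer ether chain at this place would exceed 2-methoxyethyl. As far as these compounds go, since each number comes from a single concentration, how these steps translate into potency also remains open.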